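The source may report more compounds than this note shows. Statements on the series, on what has been measured and on what is new or still open speak of the compounds shown alone.

In a physicochemical assay for lipophilicity, in phosphate buffer, measured as octanol-water partition (on this read-out higher numbers stand for higher lipophilicity and lower numbers for lower lipophilicity), the measured compounds are:
compound 1 `CCCc1nc2ccccc2c(=O)n1/N=C/c1ccc(Oc2ccc(Cl)c(C)c2)cc1`, 6.02;
compound 2 `O=c1c2ccccc2nc(-c2ccccc2)n1/N=C/c1ccc(Oc2ccccc2)cc1`, 6.13;
compound 3 `CCCc1nc2ccccc2c(=O)n1/N=C/c1ccc(Oc2ccccc2)cc1`, 5.2.

Compound 2 and compound 1 sit within the scatter of each other; compound 3 stands apart, a number 0.93 log units lower from compound 2 to compound 3 (beyond the scatter). Compound 4 `O=c1c2ccccc2nc(-c2ccccc2)n1/N=C/c1ccc(Oc2ccc(F)cc2)cc1` differs from compound 2 by fluoro in place of hydrogen on an aromatic carbon. For the measured compounds named here, no measured step alters that position. The nearest comparison is a number 0.82 log units lower from compound 1 to compound 3 (beyond the scatter), a modest step for a larger change on the same six-membered ring. A single fluoro is a smaller addition, and a small rise in this assay, at most at the edge of the scatter, is expected: a number 0.17 log units higher from compound 2 to compound 4 (within the scatter). Compound 4 is estimated at 6.3, expected between 6 and 6.6.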

Compound 4, partition coefficient: 6.21
Beside the measured number, compound 4's estimate is 0.09 log units above it, within the range that was stated.
By their numbers in this assay, from the lowest: compound 3; then compounds 1, 2 and 4 (each within the scatter of the next).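

Phenoxy to 4-fluorophenoxy on the phenyl-bearing core gives a number 0.08 log units higher from compound 2 to compound 4 (within the scatter) in this assay, so this position takes a single fluoro with no readable shift in lipophilicity. The larger change on the same ring, seen on the propyl-bearing core, gives a number 0.82 log units lower from compound 1 to compound 3 (beyond the scatter). No independent data bear on this result.

As far as these compounds go, whether fluoro gives the same small step on compound 3 remains open. Also open, from the compounds shown here alone, is what an amine or a carboxylic acid would give at this position.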